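The compounds below may be only part of what the source reports. "The series", "measured", "known", "first", "only" and "open" are said of these compounds alone.

In a functional assay on A549 cells (Homo sapiens) for antiproliferative activity, read by MTT assay, with a stated time of 48 h (on this read-out higher numbers stand for weaker inhibition and lower numbers for stronger inhibition), compound 3 (`COCOC/C1=C/C[C@](C)(CCC=C(C)C)/C=C/[C@@H](OC(=O)C=C(C)C)[C@](C)(O)/C=C/C1=O`) gives 2980 nM as the highest of three numbers, while compound 1 (`CC(C)=CCC[C@]1(C)/C=C/[C@@H](OC(=O)C=C(C)C)[C@](C)(O)/C=C/C(=O)/C(CN(C)C)=C\C1`) gives 590 nM and compound 2 (`CC(C)=CCC[C@]1(C)/C=C/[C@@H](OC(=O)C=C(C)C)[C@](C)(O)/C=C/C(=O)/C(CN2CCCC2)=C\C1`) gives 180 nM on the same read-out. Compound 4 (`CC(C)=CCC[C@]1(C)/C=C/[C@@H](OC(=O)C=C(C)C)[C@](C)(O)/C=C/C(=O)/C(COC(=O)c2ccc([N+](=O)[O-])cc2)=C\C1`) comes from compound 3 through one change ((4-nitrophenyl)carbonyl in place of methoxymethyl on an oxygen on a saturated carbon), (4-nitrophenyl)carbonyl in place of methoxymethyl on an oxygen on a saturated carbon. The nearest measured evidence is the modest 5.1-fold higher number from compound 1 to compound 3 (0.70 log units; beyond the scatter) and the large 17-fold higher number from compound 2 to compound 3 (1.22 log units; beyond the scatter) at this same carbon. Among the compounds with values here, the oxygen stays in compound 4, and no measured compound carries (4-nitrophenyl)carbonyl, so these steps guide only weakly. No step beyond the scatter is therefore expected in this assay. The estimate means a 1.5-fold lower number from compound 3 to compound 4 (0.17 log units; within the scatter) as the expected step. For compound 4 the estimated value is 2000 nM with 500 nM to 7000 nM as its expected range.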

Compound 4, half-maximal inhibitory concentration: 1310 nM
Estimate against measurement, compound 4: 1.5-fold (0.18 log units) above; the range from low to high includes it.
By their numbers in this assay, from the lowest: compound 2; then compound 1; then compound 4; then compound 3.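

In this assay, the group on this oxygen matters, not just the oxygen itself: a 2.3-fold lower number from compound 3 to compound 4 (0.36 log units; beyond the scatter). Replacing either nitrogen group with ((4-nitrophenyl)carbonyl)oxy still raises the number, with a 2.2-fold higher number from compound 1 to compound 4 (0.35 log units; beyond the scatter) and a 7.3-fold higher number from compound 2 to compound 4 (0.86 log units; beyond the scatter), so both nitrogen-linked compounds stay ahead of both oxygen-linked ones. No measured evidence here accounts for these differences. Open, as far as these compounds go, is whether a free hydroxyl or a plain acetyl group on this oxygen would fall with the oxygen-linked compounds. Also open, from the compounds shown here alone, is whether a piperidine or morpholine ring on this carbon would match pyrrolidin-1-yl.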